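A few compounds are considered here, and "the series" means these few. Any claim that something is new, unique, unknown or untested is made for them only; others in the source may bear on it.

Among the compounds with values here, in a functional assay on MOLM-13 cells (Homo sapiens) for antiproliferative activity (a higher number here means a weaker inhibitor, a lower number a stronger inhibitor), two compounds that share one core have numbers so far. Compound 1 `Cc1c(-c2ccc(-c3ccccc3F)cc2)nc2ccc(F)cc2c1CO`, with hydroxymethyl on an aromatic carbon, gives 700 nM. Compound 2 `Cc1c(-c2ccc(-c3ccccc3F)cc2)nc2ccc(F)cc2c1C(N)=O`, with carbamoyl there instead, gives 128 nM, the lower of the two numbers. Compound 3 `CCONC(=O)c1c(C)c(-c2ccc(-c3ccccc3F)cc2)nc2ccc(F)cc12` keeps all of compound 2 except for one change: ethoxy in place of hydrogen on an amide-type nitrogen, which turns carbamoyl into ethoxycarbamoyl. Within the data shown here, the only measured step, a 5.5-fold lower number from compound 1 to compound 2 (0.74 log units; beyond the scatter), replaces the whole group on that aromatic carbon. It shows that the number can shift with this group, but it does not test a change on the nitrogen, so it gives only a loose guide. A modest move toward a higher number is expected, smaller than that step and quite uncertain. The expected change is a 2.3-fold higher number from compound 2 to compound 3 (0.37 log units; beyond the scatter). For compound 3, the estimated value is 300 nM, with an expected range from 90 nM to 1000 nM.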

Compound 3, half-maximal inhibitory concentration: 33 nM
Compound 3: the middle estimate sits 9.1-fold (0.96 log units) above what was measured; the measured number lies below the stated range.
By their numbers in this assay, from the lowest: compound 3; then compound 2; then compound 1.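

In this assay, the amide nitrogen itself turns out to be a place where the number can still fall: ethoxy in place of the amide hydrogen gives a 3.9-fold lower number from compound 2 to compound 3 (0.59 log units; beyond the scatter). Earlier, only the whole group on the aromatic carbon had been exchanged, whereas this change keeps the carbonyl and adds to the nitrogen, and the full exchange of hydroxymethyl for ethoxycarbamoyl amounts to a 21-fold lower number from compound 1 to compound 3 (1.33 log units; beyond the scatter). No measurement shown here explains why the number falls with ethoxy on this nitrogen.

The compounds shown leave open whether the oxygen of ethoxy matters, which a plain propyl group on the same nitrogen would test, and whether methoxy or a longer chain such as butoxy would move the number further. On these data alone, how a carboxylic acid on that aromatic carbon would compare also remains open.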